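Hydroxyalkoxy variation on the chlorophenyl isoindolinone series

The compounds below may be only part of what the source reports. "The series", "measured", "known", "first", "only" and "open" are said of these compounds alone.

Compound 2 `CC(C)(CO)COC1(c2ccc(Cl)cc2)c2ccccc2C(=O)N1Cc1ccccc1` gives 71000 nM in a functional assay on HCT-116 cells (Homo sapiens) for inhibition, read by fluorescence, with a stated time of 48 h; on this read-out higher numbers stand for weaker inhibition of growth and lower numbers for stronger inhibition of growth. Compound 1 `O=C1c2ccccc2C(OCCCO)(c2ccc(Cl)cc2)N1Cc1ccccc1` gives 79000 nM in this assay, the change being (2-hydroxyethyl in place of 1-(hydroxymethyl)-1-methylethyl on a saturated chain carbon bound to an oxygen on a saturated carbon); the step of a 1.1-fold higher number from compound 2 to compound 1 (0.05 log units; within the scatter). Compound 3 `CC(C)(CO)COC1(c2ccc(Cl)cc2)c2ccccc2C(=O)N1Cc1ccc(Cl)cc1` differs from compound 2 by chloro in place of hydrogen on an aromatic carbon; in this assay compound 3 gives 50000 nM, and the step of a 1.4-fold lower number from compound 2 to compound 3 (0.15 log units; within the scatter). All three values sit within the scatter of one another.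

Compound 4 `O=C1c2ccccc2C(OCCCO)(c2ccc(Cl)cc2)N1Cc1ccc(Cl)cc1` is not yet measured. It differs from compound 3 by 2-hydroxyethyl in place of 1-(hydroxymethyl)-1-methylethyl on a saturated chain carbon bound to an oxygen on a saturated carbon, the same change as from compound 2 to compound 1, made here on the core of compound 3. Because the step of a 1.1-fold higher number from compound 2 to compound 1 (0.05 log units; within the scatter) was within the scatter, the step from compound 3 to compound 4 is expected to be a 1.1-fold higher number from compound 3 to compound 4 (0.04 log units; within the scatter). Compound 4 is therefore estimated at 55000 nM in this assay, between 25000 nM and 110000 nM.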

Compound 4, concentration for 50% growth inhibition: 60000 nM
Estimate against measurement, compound 4: 1.1-fold (0.04 log units) below, within the range that was stated.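

In this assay, 2-hydroxyethyl in place of 1-(hydroxymethyl)-1-methylethyl gives a 1.2-fold higher number from compound 3 to compound 4 (0.08 log units; within the scatter), and this agrees with the step on the other core: the same change on two cores in this assay, a 1.1-fold higher number (0.05 log units; within the scatter) from compound 2 to compound 1 and a 1.2-fold higher number (0.08 log units; within the scatter) from compound 3 to compound 4, 1.1-fold (0.03 log units) apart, within the scatter of two such steps. Chloro in place of hydrogen on an aromatic carbon gives a 1.3-fold lower number from compound 1 to compound 4 (0.12 log units; within the scatter), and this also agrees with its earlier step: the same change on two cores in this assay, a 1.4-fold lower number (0.15 log units; within the scatter) from compound 2 to compound 3 and a 1.3-fold lower number (0.12 log units; within the scatter) from compound 1 to compound 4, 1.1-fold (0.03 log units) apart, within the scatter of two such steps. Among these compounds, all of these steps lie within the scatter, so the agreement shows only that neither change gives a measurable shift on these two cores; it does not show that a real effect carries from one core to another, and it does not extend to other cores.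

On these data alone, whether an amine or a carboxylic acid in place of the hydroxy group, or a longer chain, would give a step beyond the scatter in this assay remains open.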